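Efficacy notes: methyl branching on the 2-carboxyethyl chain

The compounds below may be only part of what the source reports. "The series", "measured", "known", "first", "only" and "open" are said of these compounds alone.

Measured compounds:
compound 1 `Cc1nn(-c2ccccn2)c2cc(-c3ccc(CCC(=O)O)cc3)ccc12`, 95% in a functional assay on cells for agonist activity at Free fatty acid receptor 1 (Mus musculus), read by FLIPR and calcium flux, with a stated time of 5 min; a higher number here means a larger maximal response, a lower number a smaller maximal response
compound 2 `Cc1nn(-c2ccccn2)c2cc(-c3ccc(CCC(=O)O)cc3)ncc12`, 86% in this assay
compound 3 `CCc1nn(-c2ccccn2)c2cc(-c3ccc(CCC(=O)O)cc3)ccc12`, 93% in this assay

The change methyl in place of hydrogen on a saturated chain carbon bound to an aromatic carbon gives a number 2 percentage points lower from compound 1 to compound 3 (within the scatter) in this assay. The difference between the core of compound 1 and the core of compound 2 is not broken down here; their values in this assay lie within the scatter of each other, as do those of compound 2 and compound 3.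

Compound 4 `Cc1nn(-c2ccccn2)c2cc(-c3ccc(C(C)CC(=O)O)cc3)ncc12` carries methyl in place of hydrogen on a saturated chain carbon bound to an aromatic carbon and a saturated chain carbon. Around the place this is the same kind of change as from compound 1 to compound 3, but not the same: there the carbon was bound to an aromatic carbon only, here to an aromatic carbon and a saturated chain carbon. Because a number 2 percentage points lower from compound 1 to compound 3 (within the scatter) stayed within the scatter, a similar small step is expected, a number 2 percentage points lower from compound 2 to compound 4 (within the scatter) in this assay. Compound 4 is expected to give 84%, estimated between 70% and 96%.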

Compound 4, largest response reached (reported as efficacy), in percent of the reference or control that the assay uses: 50%
Beside the measured number, compound 4's estimate is 34 percentage points above it, and the stated range ends above it.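

In this assay the methyl gives a number 36 percentage points lower from compound 2 to compound 4 (beyond the scatter), so a step that stayed small on one core does not carry over to the other: the same change on two cores in this assay, a number 2 percentage points lower (within the scatter) from compound 1 to compound 3 and a number 36 percentage points lower (beyond the scatter) from compound 2 to compound 4, 34 percentage points apart, beyond the scatter of two such steps

The two steps also differ in place, with the methyl on a carbon bound to an aromatic carbon only in compound 3, and on one bound to an aromatic carbon and a saturated chain carbon in compound 4. The comparison therefore does not show whether the core or the place of the methyl accounts for the gap.

On these data alone, the 1-(carboxymethyl)ethyl chain on the core of compound 1 would separate the two and remains open. Also open, as far as these compounds go, is how a hydroxyl group or a fluorine atom would behave on that same chain carbon.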